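A few compounds are considered here, and "the series" means these few. Any claim that something is new, unique, unknown or untested is made for them only; others in the source may bear on it.

Measured so far in an assay on HEK293 cells for positive allosteric modulation of metabotropic glutamate receptor 5 (Homo sapiens), read by FLIPR; on this read-out higher numbers stand for an effect only at larger amounts of compound and lower numbers for an effect already at smaller amounts:
compound 1 `O=C(c1ccc(F)c(F)c1)N1CC(c2nc(-c3cccc(F)c3)no2)C1` gives 3200 nM
compound 2 `O=C(C1CCC2(CCC2)CC1)N1CC(c2nc(-c3cccc(Cl)c3)no2)C1` gives 1100 nM
compound 3 `O=S(=O)(c1ccc(Cl)cc1)N1CC(c2nc(-c3cccc(Cl)c3)no2)C1` gives > 10000 nM

The three compounds share a core and differ in the group joined to the amide-type nitrogen in a ring. Of the two numbers in hand, compound 2 gives the lowest, so it is the one that acts at the smallest amount. Compound 1 gives a higher number, and the gap between the two lies beyond the usual scatter. For compound 3 the assay reports only a limit, not a number (the limit of > 10000 nM in this assay, at which 1 of the 3 values shown sits).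

Compound 4 `CC1CCC(C(=O)N2CC(c3nc(-c4cccc(Cl)c4)no3)C2)CC1` is the new compound. It differs from compound 2 at one place: a group of 7 heavy atoms (7 carbon; one six-membered non-aromatic ring of carbon only) in place of a group of 9 heavy atoms (9 carbon; one four-membered non-aromatic ring of carbon only, one six-membered non-aromatic ring of carbon only), on a carbonyl carbon. Among the compounds with values here, no measured pair among the three compounds shows a change of this kind, so there is no measured step to lean on. Both groups are saturated carbon rings on the carbonyl carbon, and the change is modest in size, so the step of a 1.5-fold higher number from compound 2 to compound 4 (0.16 log units; within the scatter) is expected to be small, leaning toward a somewhat higher number, and may well stay within the scatter. Compound 4 is therefore estimated at 1600 nM, with a range from 600 nM to 4500 nM.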

Compound 4, half-maximal effective concentration: 1500 nM
The estimate for compound 4 lay 1.1-fold (0.03 log units) above the measured number; the measured number falls inside the stated range.
By their numbers in this assay, from the lowest: compounds 2 and 4 (each within the scatter of the next); then compound 1. At a limit, above all of these: compound 3.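

In this assay, putting 4-methylcyclohexyl in place of the group of 9 heavy atoms on the carbonyl carbon gives a 1.4-fold higher number from compound 2 to compound 4 (0.13 log units; within the scatter). Within the data shown here, this is the first measured step at this position with everything else in the molecule held constant, and it shows that the four-membered ring of compound 2 can be lost with no change that can be told apart from the scatter. The finding rests on this one pair, and nothing measured here explains why the two groups read alike.

The compounds shown leave open how far this tolerance extends, since both groups in the pair are saturated carbon rings with no hydrogen-bond donors or acceptors, and it is not known how an unsubstituted cyclohexyl, or a six-membered ring carrying an amine or a carboxylic acid, would read at the same place. Also open, as far as these compounds go, is what a change elsewhere would do with 4-methylcyclohexyl held in place. Compound 1 differs from compound 4 in more than one place and so cannot settle that.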